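Chloro on the outer phenyl of compound 2

A few compounds are considered here, and "the series" means these few. Any claim that something is new, unique, unknown or untested is made for them only; others in the source may bear on it.

Compound 2 `COc1cc(CSc2cc(Cl)c(-c3nc(-c4ccccc4)no3)cc2S(=O)(=O)NC(=N)NO)cc(OC)c1OC` gives the highest of the three numbers in a functional assay on NCI-H522 cells (Homo sapiens) (on this read-out higher numbers stand for weaker inhibition of growth and lower numbers for stronger inhibition of growth), namely 3800 nM. Compound 1 `N=C(NO)NS(=O)(=O)c1cc(-c2nnc(-c3ccc(Cl)cc3)s2)c(Cl)cc1SCc1ccccc1` gives 1670 nM in this assay, and compound 3 `N=C(NO)NS(=O)(=O)c1cc(-c2nc(-c3ccccc3)no2)c(Cl)cc1SCc1ccccc1` gives 1320 nM. For the measured compounds named here, the one single-point step among them, a 2.9-fold lower number from compound 2 to compound 3 (0.46 log units; beyond the scatter), concerns the benzyl side of the molecule, not the outer phenyl. Compound 4 `COc1cc(CSc2cc(Cl)c(-c3nc(-c4ccc(Cl)cc4)no3)cc2S(=O)(=O)NC(=N)NO)cc(OC)c1OC` differs from compound 2 by chloro in place of hydrogen on an aromatic carbon. Going by the values given here, no measured step isolates this change; compounds 1 and 3 carry it together with a second difference, and their two values lie within the scatter of each other. He therefore expects no step beyond the scatter, a 1.1-fold lower number from compound 2 to compound 4 (0.05 log units; within the scatter). For compound 4 he estimates 3400 nM, with a range from 1500 nM to 8000 nM.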

Compound 4, concentration for 50% growth inhibition: 2140 nM
Beside the measured number, compound 4's estimate is 1.6-fold (0.20 log units) above it, and the stated range covers the measured number.
By their numbers in this assay, from the lowest: compounds 3, 1, 4 and 2 (each within the scatter of the next, the first and the last beyond it).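

With the 3,4,5-trimethoxyphenyl group held constant, the chloro change can now be read on its own: in this assay there is a 1.8-fold lower number from compound 2 to compound 4 (0.25 log units; within the scatter). Chloro can therefore stand at this position, para to a large group, without a step that can be told from the scatter. Nothing measured here bears on the reason for this result. Going by these compounds, whether chloro behaves alike with phenyl in place of 3,4,5-trimethoxyphenyl, as in compound 3, stays open. So does whether an amine or a carboxylic acid here would give a step beyond the scatter.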